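Pyridazinone amides: the step from compound 3 to compound 4

The compounds below may be only part of what the source reports. "The series", "measured", "known", "first", "only" and "open" are said of these compounds alone.

Compound 1, `COc1cccc(Cc2cc(-c3ccccc3)nn(CC(=O)Nc3ccc(Br)cc3)c2=O)c1`. In an assay on HL-60 cells for agonist activity at N-formyl peptide receptor 3 (Homo sapiens), read by calcium flux (on this read-out lower numbers stand for an effect already at smaller amounts and higher numbers for an effect only at larger amounts of compound), compound 1 gives > 50000 nM, which is a limit of the assay, not a number.
Compound 2, `COc1cccc(Cc2cc(-c3ccccc3)nn(CC(=O)Nc3ccc(F)cc3)c2=O)c1`. In this assay compound 2 gives > 50000 nM, again a limit.
Compound 3, `Cc1cc(Cc2cccc(F)c2)c(=O)n(CC(=O)Nc2ccc(Br)cc2)n1`. In this assay compound 3 gives > 50000 nM, also a limit.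

Compound 3 therefore stands where every measured compound stands, at the limit of this assay, and no number separates it from the others. Among the measured compounds shown here, the only measured pair that differs in one place is a step that the two limits leave unreadable from compound 1 to compound 2, and the two limits leave its size unreadable. All that the measurements show is the limit of > 50000 nM in this assay, at which 3 of the 3 values shown sit.

Compound 4, `Cc1cc(Cc2ccc(C#N)cc2)c(=O)n(CC(=O)Nc2ccc(Br)cc2)n1`, is not yet measured. It differs from compound 3 by 4-cyanophenyl in place of 3-fluorophenyl on a saturated chain carbon bound to an aromatic carbon.

For the measured compounds named here, no measured step bears on this change, and the three limits give no direction. The expectation for this assay is therefore that compound 4 is estimated to give 50000 nM, between 10000 nM and 100000 nM, most probably as a further limit. The estimated step of a number no higher from compound 3 to compound 4 (the limit leaves the size open) is expected to be none beyond the scatter.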

Compound 4, half-maximal effective concentration: > 50000 nM
Compound 4 was reported as a limit; the forecaster's own chance of this, stated with the estimate: 80%; the middle value sits exactly at the limit.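

Compound 3 and compound 4 both stand at a limit in this assay and not at a number, and the step between them cannot be read. The compounds shown leave open whether 3-fluorobenzyl and 4-cyanobenzyl differ at all here, and whether any change to the shared core gives a readable value in this assay.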